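Swapping a Benzyl Group for Naphthyl: Expected Permeability

This account rests on a few compounds, and the source may have more. Where it says the series, first, only, none or still open, it means among the compounds named here.

Measured compounds:
compound 1 `COc1ccc(F)cc1CNCCCNc1ccnc2cc(Cc3cc(C)cc(C)c3)ccc12`, in an ADME assay for permeability, using PAMPA, with a stated time of 30 min, at pH 7.4; a lower number here means that the compound crosses the layer more slowly, a higher number that the compound crosses the layer faster: 23 10^-6 cm/s
compound 2 `COc1ccc(Oc2ccc3c(NCCCNCc4cccc(OC)c4O)ccnc3c2)cc1`: 317 10^-6 cm/s
compound 3 `Cc1cc(C)cc(Cc2ccc3c(NCCCNCc4ccco4)ccnc3c2)c1`: 23 10^-6 cm/s

Compound 1 stands level with compound 3 at the digits shown, and together they hold the lowest of the three numbers; compound 2 lies furthest from compound 1, with a number beyond the scatter. Compound 4 `COc1ccc(F)cc1CNCCCNc1ccnc2cc(-c3cccc4ccccc34)ccc12` differs from compound 1 in one place: naphthalen-1-yl in place of 3,5-dimethylbenzyl on an aromatic carbon. Among the compounds with values here, the only single measured step, no change at the digits printed from compound 1 to compound 3 (within the scatter), concerns a saturated chain carbon bound to an amine nitrogen, not the aromatic carbon changed here, so it offers no direct guide. Without a measured step for this kind of change, compound 4 is expected to stay near compound 1, with a step of a 1.3-fold higher number from compound 1 to compound 4 (0.12 log units; within the scatter). For compound 4 the estimated value in this assay is 30 10^-6 cm/s, with a range from 10 10^-6 cm/s to 90 10^-6 cm/s.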

Compound 4, apparent permeability: 237 10^-6 cm/s
The estimate for compound 4 lay 7.9-fold (0.90 log units) below the measured number; the measured number lies above the stated range.
By their numbers in this assay, from the lowest: compounds 1 and 3 (each within the scatter of the next); then compounds 4 and 2 (each within the scatter of the next).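

In this assay, within the data shown here, the group on this aromatic carbon of the shared core proves decisive: naphthalen-1-yl in place of 3,5-dimethylbenzyl gives a 10-fold higher number from compound 1 to compound 4 (1.01 log units; beyond the scatter), whereas the only earlier step, at a saturated chain carbon, gave no change at the digits printed from compound 1 to compound 3 (within the scatter). Neither group carries hydrogen-bond donors or acceptors, but the entering group has 2 six-membered aromatic rings of carbon only and the leaving group has one. Nothing available explains why the number rises. As far as these compounds go, it remains open whether the rise follows from the second ring or from losing the benzyl carbon that links the ring to the core. A plain phenyl group on the same aromatic carbon would help separate the two.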